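Carboxy in Place of Tetrazole: A Step Taken Twice

The source may hold more compounds than are shown below. What is called first, only, known or untested is meant among the compounds shown, and "the series" means these compounds.

Compound 1 `COc1ccc2ncc(-c3nn[nH]n3)cc2c1` is tested in a functional assay on the whole organism (strain Sprague-Dawley) for inhibition, with Rattus norvegicus as the target (on this read-out higher numbers stand for an effect only at larger amounts of compound and lower numbers for an effect already at smaller amounts), where compound 1 gives 10 mg/kg. Compound 2 `COc1ccc2ncc(C(=O)O)cc2c1` differs from it by carboxy in place of 2H-tetrazol-5-yl on an aromatic carbon. In this assay compound 2 reaches only a limit, > 5 mg/kg. The step that the limit leaves unreadable from compound 1 to compound 2 therefore cannot be sized, because of the limit of > 5 mg/kg in this assay, at which 1 of the 3 values shown sits.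

Compound 3 `COc1ccc(OC)c2ncc(-c3nn[nH]n3)cc12` gives 5 mg/kg in this assay. The difference between the core of compound 3 and that of compound 1 is not broken down here.

Compound 4 `COc1ccc(OC)c2ncc(C(=O)O)cc12` has not been measured; it differs from compound 3 by carboxy in place of 2H-tetrazol-5-yl on an aromatic carbon, the same change made from compound 1 to compound 2. Because the step that the limit leaves unreadable from compound 1 to compound 2 ran toward the limit, compound 4 is expected to sit at about 15 mg/kg, likely between 5 mg/kg and 50 mg/kg, with an expected step of a 3.0-fold higher number from compound 3 to compound 4 (0.48 log units; beyond the scatter), and a real chance that only a limit is read.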

Compound 4, minimum effective dose: > 25 mg/kg
Compound 4 gave a limit, no number; the forecaster's own chance of this, stated with the estimate: 65%; middle value at least 1.6-fold (0.22 log units) from the limit.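

In this assay, putting carboxy in place of 2H-tetrazol-5-yl gives an at least 5.0-fold higher number from compound 3 to compound 4 (0.69 log units; beyond the scatter), so on this core the change means that more compound is needed for an effect. As far as these compounds go, compound 4 reaches only a limit, > 25 mg/kg, so the true size of this step stays unknown. Whether the change costs as much on the core of compound 1 cannot be said, because compound 2 also gives only a limit: the limit of > 5 mg/kg in this assay, at which 1 of the 4 values shown sits.

The compounds shown leave open how an amide or an amine would do in place of the 2H-tetrazol-5-yl on either core. They also leave open whether any other core would respond to the change in the same way.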